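Swapping a nitrile for fluoro in a weak inhibitor

The source may report more compounds than this note shows. Statements on the series, on what has been measured and on what is new or still open speak of the compounds shown alone.

Measured in an ADME assay on CHO cells (Cricetulus griseus) for inhibition, read by MTT assay; a lower number here means a stronger inhibitor, a higher number a weaker inhibitor:
- Compound 1 `CC(C)(C)NCc1cc(Cl)cc(Nc2nc3ccccc3n2Cc2ccc(C(F)(F)F)cc2)c1O`: 36300 nM
- Compound 2 `CCN(CC)Cc1cccc(Nc2nc3ccccc3n2Cc2ccc(C#N)cc2)c1O`: > 50000 nM
- Compound 3 `CCN(CC)Cc1cc(Nc2nc3ccccc3n2Cc2ccc(C(F)(F)F)cc2)ccc1O`: 17500 nM

Compound 2 reads > 50000 nM in this assay, and this is a limit of the assay, not a number. Its true position is therefore unknown. Only compound 1 and compound 3 give actual numbers, and both carry a trifluoromethyl group where compound 2 carries a cyano group. Among the measured compounds shown here, they also differ from compound 2 elsewhere, so no measured pair shows the effect of changing this group alone.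

Compound 4 `CCN(CC)Cc1cccc(Nc2nc3ccccc3n2Cc2ccc(F)cc2)c1O` is compound 2 with fluoro in place of cyano on an aromatic carbon, para to a large group, so 4-cyanobenzyl becomes 4-fluorobenzyl: fluoro in place of cyano on an aromatic carbon.

For the measured compounds named here, with no measured step as a guide, no change beyond the scatter is expected in this assay. That expectation starts from compound 2, the closest relative, with its limit of > 50000 nM. The estimated step is an at least 1.1-fold lower number from compound 2 to compound 4 (0.04 log units; that floor lies within the scatter). The assay may well report only a limit again. For compound 4 the expected value is 45000 nM, with an estimated range of 20000 nM to 80000 nM.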

Compound 4, half-maximal inhibitory concentration: > 50000 nM
Compound 4 ended at the assay's limit (the forecaster's own chance of this, stated with the estimate: 50%); at least 1.1-fold (0.04 log units) between middle value and limit.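

Compound 4 gives no new step from compound 2 in this assay, because both compounds sit at the same limit of the assay, so the gap between them cannot be read: the limit of > 50000 nM in this assay, at which 2 of the 4 values shown sit.

The compounds shown leave open whether fluoro in place of cyano on the benzyl group changes inhibition at all, and how strong either compound truly is.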